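Chloro added to the benzyl ring of a urea analogue

This account rests on a few compounds, and the source may have more. Where it says the series, first, only, none or still open, it means among the compounds named here.

Measured so far:
compound 1 `Cc1ccc(NC(=S)NC(=O)c2ccc(OCc3cccc(C(F)(F)F)c3)cc2)cc1-c1nc2ccccc2[nH]1` gives 6050 nM
compound 2 `Cc1ccc(NC(=O)NC(=O)c2ccc(OCc3ccccc3)cc2)cc1-c1nc2ccccc2[nH]1` gives 35100 nM

Both numbers come from a functional assay on MNK45 cells (Homo sapiens) for inhibition, read by MTT assay, with a stated time of 48 h; a higher number here means a weaker inhibitor, a lower number a stronger inhibitor. Compound 2 stands at the higher of the two values; compound 1 sits at a number that is lower by a margin beyond the usual scatter, but compound 1 differs from compound 2 in two places at once, so the two values alone do not separate those changes.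

Compound 3 `Cc1ccc(NC(=O)NC(=O)c2ccc(OCc3cccc(Cl)c3)cc2)cc1-c1nc2ccccc2[nH]1` keeps the urea of compound 2 and introduces a single change, (chloro in place of hydrogen on an aromatic carbon). Going by the values given here, no measured pair isolates this change here. The step from compound 2 to compound 3 is therefore expected to be modest, most likely toward a lower number, though a result within the scatter would not surprise; the expected step is a 2.3-fold lower number from compound 2 to compound 3 (0.37 log units; beyond the scatter). Compound 3 is estimated at 15000 nM, within a range from 5000 nM to 45000 nM.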

Compound 3, half-maximal inhibitory concentration: 28000 nM
For compound 3 the middle estimate is 1.9-fold (0.27 log units) below the measured one, within the range that was stated.
By their numbers in this assay, from the lowest: compound 1; then compounds 3 and 2 (each within the scatter of the next).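

In this assay, with the urea held fixed, replacing benzyl with 3-chlorobenzyl gives a 1.3-fold lower number from compound 2 to compound 3 (0.10 log units; within the scatter). Going by these compounds alone, this is the first single change that can be read in this set, and it shows that chloro in place of hydrogen on this aromatic carbon makes no difference beyond the scatter. No separate measurement bears on this result.

Compound 1 differs from compound 3 in two places, the thiourea and the trifluoromethyl, so the compounds shown do not tell which of these, if either, accounts for the value of compound 1. Also open, going by these compounds, is how a different group on this same aromatic carbon, such as a methoxy group, an amine or a carboxylic acid, would compare with chloro on the urea.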